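Cyclohexyl to 4-Fluorophenyl on a Piperazine Nitrogen

A few compounds are considered here, and "the series" means these few. Any claim that something is new, unique, unknown or untested is made for them only; others in the source may bear on it.

Compound 1: `COc1cc2c(cc1OC)CN(CCCCn1nc(-c3ccccc3)oc1=O)CC2`, 864 nM
Compound 2: `O=c1oc(-c2ccccc2)nn1CCCCN1CCc2ccc([N+](=O)[O-])cc2C1`, 383 nM
Compound 3: `O=C1CCc2ccccc2N1CCCCN1CCN(C2CCCCC2)CC1`, 1.5 nM

In an assay on membranes from liver for displacement of a labelled ligand from Sigma intracellular receptor 2 (Rattus norvegicus), read by scintillation counting, with a stated time of 120 min, in the presence of a further agent that is not named here (on this read-out lower numbers stand for stronger inhibition and higher numbers for weaker inhibition), compound 3 gives the lowest number of the three; the nearest, compound 2, and the furthest, compound 1, both sit beyond the usual scatter, so compound 3 is clearly the strongest binder here. For the measured compounds named here, no pair among the measured compounds differs in one place only, so no single-change step can be read off directly.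

Compound 4 is `O=C1CCc2ccccc2N1CCCCN1CCN(c2ccc(F)cc2)CC1`. Going by the values given here, its one difference from compound 3 is 4-fluorophenyl in place of cyclohexyl on an amine nitrogen in a ring. Among the compounds with values here, with no measured step of this kind to lean on, a modest weakening in this assay is expected for compound 4, a step of a 5.3-fold higher number from compound 3 to compound 4 (0.73 log units; beyond the scatter). The estimate for compound 4 is 8 nM, with a range from 1.5 nM to 60 nM.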

Compound 4, inhibition constant: 21 nM
Beside the measured number, compound 4's estimate is 2.6-fold (0.42 log units) below it; low and high end bracket the measured number.
By their numbers in this assay, from the lowest: compound 3; then compound 4; then compound 2; then compound 1.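

For the compounds shown here, this is the first measured change on the amine nitrogen in the ring: in this assay, 4-fluorophenyl in place of cyclohexyl gives a 14-fold higher number from compound 3 to compound 4 (1.15 log units; beyond the scatter), a large step beyond the usual scatter. Binding therefore depends strongly on which six-membered ring sits here, although both groups count no hydrogen-bond donors or acceptors and no net charge. Nothing at hand explains the weakening.

From the compounds shown here alone, whether the aromatic ring or the fluorine matters more stays open; a plain phenyl on this nitrogen would separate the two. Going by these compounds, how a small methyl here would compare also remains unknown.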